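Replacing a hydrazide with a methyl ester: expected solubility

The compounds below may be only part of what the source reports. "The series", "measured", "known", "first", "only" and "open" are said of these compounds alone.

Measured compounds:
compound 1 `Cc1cc(/C=C/C#N)cc(C)c1Oc1cc(Nc2ccc(C#N)cc2)c(N)cc1C(=O)NN` – 89.6 ug/mL
compound 2 `Cc1cc(/C=C/C#N)cc(C)c1Oc1cc(Nc2ccc(C#N)cc2)c(N)cc1C(N)=O` – 2.09 ug/mL

In a physicochemical assay for solubility, read by HPLC, with a stated time of 4 h, at pH 2 (on this read-out higher numbers stand for higher solubility and lower numbers for lower solubility), compound 1 gives 89.6 ug/mL, the higher of the two numbers measured. Compound 2 gives 2.09 ug/mL in this assay. Within the data shown here, the one measured step, a 43-fold lower number from compound 1 to compound 2 (1.63 log units; beyond the scatter), took away only the outer amino of the aminoamino group on the carbonyl carbon and left a plain amide.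

Compound 3 `COC(=O)c1cc(N)c(Nc2ccc(C#N)cc2)cc1Oc1c(C)cc(/C=C/C#N)cc1C` is not yet measured. Its change from compound 1 is methoxy in place of aminoamino on a carbonyl carbon, so both nitrogens of the aminoamino group are gone and a methoxy takes their place. Among the measured compounds shown here, that change goes further than the one measured step, which was already large, so a step downward in this assay, at least as large, is expected. Compound 3 is therefore estimated at 1.5 ug/mL, with a range from 0.3 ug/mL to 8 ug/mL, an expected step of a 60-fold lower number from compound 1 to compound 3 (1.78 log units; beyond the scatter).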

Compound 3, solubility: 21.8 ug/mL
The estimate for compound 3 lay 15-fold (1.16 log units) below the measured number; the measured number lies above the stated range.
By their numbers in this assay, from the lowest: compound 2; then compound 3; then compound 1.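

In this assay, putting methoxy in place of aminoamino on the carbonyl carbon gives a 4.1-fold lower number from compound 1 to compound 3 (0.61 log units; beyond the scatter) and so removes both nitrogens for a smaller step than the one seen when only the outer amino left. Methoxy in place of the amino of the plain amide gives a 10-fold higher number from compound 2 to compound 3 (1.02 log units; beyond the scatter) and places the compound with no nitrogen on this carbonyl carbon between the other two, so the numbers do not simply fall as nitrogens are removed. Nothing measured here explains this order.

The compounds shown leave open where a carboxylic acid, an ethoxy group or a methylamino group on the same carbonyl carbon would fall. They also leave open whether this order would hold on a different core.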